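Biphenyl Amide Variant of a Flavonol Series

This account rests on a few compounds, and the source may have more. Where it says the series, first, only, none or still open, it means among the compounds named here.

Measured so far:
Compound 1 `O=C(Nc1cccc(-c2oc3cc(-c4ccc(F)cc4)ccc3c(=O)c2O)c1)c1ccc(C(F)(F)F)cc1`: 7350 nM
Compound 2 `COc1ccc(C(=O)Nc2cccc(-c3oc4cc(-c5ccc(F)cc5)ccc4c(=O)c3O)c2)c(F)c1`: 24500 nM

Among the compounds with values here, in a functional assay on HCC1937 cells (Homo sapiens) for antiproliferative activity, read by CCK-8 assay, with a stated time of 72 h (on this read-out higher numbers stand for weaker inhibition and lower numbers for stronger inhibition), compound 2 stands as the higher of the two numbers, and the only step recorded, a 3.3-fold higher number from compound 1 to compound 2 (0.52 log units; beyond the scatter), lies beyond the scatter. Compound 3 `O=C(Nc1cccc(-c2oc3cc(-c4ccc(F)cc4)ccc3c(=O)c2O)c1)c1ccc(-c2ccccc2)cc1` differs from compound 2 in one place: 4-phenylphenyl in place of 2-fluoro-4-methoxyphenyl on a carbonyl carbon. Within the data shown here, only that one step bears on this change, and it was modest. Among the measured compounds shown here, compound 3 is expected to move back toward the level of compound 1, with a step of a 3.1-fold lower number from compound 2 to compound 3 (0.49 log units; beyond the scatter) downward, though the single comparable step makes this uncertain. The estimate for compound 3 in this assay is 8000 nM, within a range of 2500 nM to 30000 nM.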

Compound 3, half-maximal inhibitory concentration: 44100 nM
Compound 3: middle estimate off by 5.5-fold (0.74 log units), on the low side; measured number outside the range, above it.
By their numbers in this assay, from the lowest: compound 1; then compounds 2 and 3 (each within the scatter of the next).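

In this assay the larger 4-phenylphenyl group in place of 2-fluoro-4-methoxyphenyl gives a 1.8-fold higher number from compound 2 to compound 3 (0.26 log units; within the scatter) and so cannot be told apart from it. The clearer comparison is phenyl in place of trifluoromethyl on an aromatic carbon, which gives a 6.0-fold higher number from compound 1 to compound 3 (0.78 log units; beyond the scatter) and shows that the added second aromatic ring does not bring the number down. Nothing measured here explains this result.

Still open, as far as these compounds go, is how a smaller group, such as chlorine or a nitrile, would compare in place of trifluoromethyl on that aromatic carbon. An amine or a carboxylic acid there also remains an open question.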